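Swapping an imidazole for a substituted pyridine: an estimated lipophilicity

This account rests on a few compounds, and the source may have more. Where it says the series, first, only, none or still open, it means among the compounds named here.

Measured so far:
compound 1 `Cc1nccn1-c1cnc(NCc2c(F)ccc3c2CCO3)c2cn[nH]c(=O)c12` gives 2.1
compound 2 `CN(c1ccccc1)c1cnc(NCc2c(F)ccc3c2CCO3)n2cnnc12` gives 3.6
compound 3 `CN(c1ccn(C)n1)c1cnc(NCc2c(F)ccc3c2CCO3)n2cnnc12` gives 1.8

These three numbers come from a physicochemical assay for lipophilicity, using the shake flask method, in phosphate buffer, measured as octanol-water partition, with a stated time of 30 min, at pH 7.4; on this read-out higher numbers stand for higher lipophilicity and lower numbers for lower lipophilicity. Compound 1 stands second highest of the three; compound 3 lies within the usual scatter of it, while compound 2 sits well above. Within the data shown here, the only single-point step among the measured compounds is a number 1.80 log units lower from compound 2 to compound 3 (beyond the scatter), a large fall when a phenyl ring gives way to a 1-methyl-1H-pyrazol-3-yl ring on a nitrogen.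

Compound 4 `CNC(=O)c1ccc(-c2cnc(NCc3c(F)ccc4c3CCO4)c3cn[nH]c(=O)c23)c(C)n1` has not yet been measured. Compared with compound 1 the change is 2-methyl-6-(methylcarbamoyl)pyridin-3-yl in place of 2-methyl-1H-imidazol-1-yl on an aromatic carbon. Among the measured compounds shown here, no measured pair shares this exact change, so the step from compound 2 to compound 3 bears on it only in showing that exchanging one aromatic ring for another can move this read-out far beyond the scatter. Here a small five-membered ring leaves and a larger six-membered ring carrying a methyl and a methylcarbamoyl group enters, so a rise beyond the scatter is expected, though the amide may hold it moderate. The expected step is estimated as a number 0.50 log units higher from compound 1 to compound 4 (beyond the scatter). Compound 4 is therefore estimated at 2.6, within a range from 2 to 3.2.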

Compound 4, distribution coefficient: 2.9
Estimate against measurement, compound 4: 0.30 log units below, and the stated range covers the measured number.
By their numbers in this assay, from the lowest: compounds 3 and 1 (each within the scatter of the next); then compound 4; then compound 2.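

At this aromatic carbon of the core of compound 1, putting 2-methyl-6-(methylcarbamoyl)pyridin-3-yl in place of 2-methyl-1H-imidazol-1-yl gives a reading in this assay of a number 0.80 log units higher from compound 1 to compound 4 (beyond the scatter). Among these compounds, the only earlier step was an exchange of one ring for another on a nitrogen, in a different core, and there the number fell; this position now has a measured change of its own, and the number rises. The entering group brings a different ring size, a methyl and a methylcarbamoyl group all at once, and nothing measured here explains the rise.

As far as these compounds go, how much of the step belongs to the pyridine ring alone stays open. So does how a carboxylic acid or a primary amine would read in place of the methylcarbamoyl group.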